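Fluoro-to-hydrogen steps across a small amide series

This account rests on a few compounds, and the source may have more. Where it says the series, first, only, none or still open, it means among the compounds named here.

Measured so far:
Compound 1, `O=C(Nc1cc(C(F)(F)F)cc(C(F)(F)F)c1)c1ccccc1O`: in an assay for inhibition of transmembrane protease serine 4 (Homo sapiens), read by fluorescence (on this read-out higher numbers stand for weaker inhibition and lower numbers for stronger inhibition), compound 1 returns only a limit, > 100000 nM.
Compound 2, `O=C(Nc1cc(C(F)(F)F)cc(C(F)(F)F)c1)c1cc(F)ccc1O`: in this assay compound 2 gives 29000 nM.
Compound 3, `O=C(Nc1cc(C(F)(F)F)ccc1F)c1cc(Cl)ccc1O`: in this assay compound 3 gives 28000 nM.

Among the compounds with values here, the one single-point step measured is hydrogen in place of fluoro on an aromatic carbon, which gives an at least 3.4-fold higher number from compound 2 to compound 1 (0.53 log units; beyond the scatter). Compound 1 sits at the limit of > 100000 nM in this assay, at which 1 of the 3 values shown sits, so the full size of that step is not fixed. Compound 3 and compound 2 lie within the scatter of each other; how their two cores differ is not broken down here.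

Compound 4, `O=C(Nc1cccc(C(F)(F)F)c1)c1cc(Cl)ccc1O`, is not yet measured. It differs from compound 3 by hydrogen in place of fluoro on an aromatic carbon. This is the same kind of change as the measured step, not the same one: in the measured step the fluoro sits meta to a large group and para to a hydroxy group, whereas here it sits ortho to a large group and para to a trifluoromethyl group.

A weaker number is expected for compound 4, resting on an at least 3.4-fold higher number from compound 2 to compound 1 (0.53 log units; beyond the scatter), with the expected step being a 2.5-fold higher number from compound 3 to compound 4 (0.40 log units; beyond the scatter). Compound 4 is estimated at 70000 nM, between 25000 nM and 200000 nM, with a real chance that only a limit is returned.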

Compound 4, half-maximal inhibitory concentration: 13000 nM
Beside the measured number, compound 4's estimate is 5.4-fold (0.73 log units) above it; measured number below the stated range.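

In this assay, hydrogen in place of fluoro gives a 2.2-fold lower number from compound 3 to compound 4 (0.33 log units; beyond the scatter). Set against the earlier step, the same change runs in opposite directions on the two cores, so neither its direction nor its size can be carried from one core to the other in this series: the same change on two cores in this assay, an at least 3.4-fold higher number (0.53 log units; beyond the scatter) from compound 2 to compound 1 and a 2.2-fold lower number (0.33 log units; beyond the scatter) from compound 3 to compound 4, at least 7.4-fold (0.87 log units) apart, beyond the scatter of two such steps

With only two pairs, and with compound 1 standing at a limit, neither the full size of the earlier step nor a reason for the opposite directions can be read from these data: the limit of > 100000 nM in this assay, at which 1 of the 4 values shown sits.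

Open, from the compounds shown here alone, is how the same replacement behaves when a nitrile or a carboxylic acid stands in place of a trifluoromethyl group, and which direction, if either, appears on a third core. Equally open, going by these compounds, is what an amine in place of the hydroxy group would do to the numbers.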